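Swapping a Phenethyl Amide for a Fluorinated Benzamide

This account rests on a few compounds, and the source may have more. Where it says the series, first, only, none or still open, it means among the compounds named here.

Measured compounds in a functional assay on A549 cells (Homo sapiens) for inhibition, read by MTT assay, with a stated time of 48 h; on this read-out higher numbers stand for weaker inhibition and lower numbers for stronger inhibition:
compound 1 `CCCCC(=O)Nc1ccc(N2CCN(c3ccc(OC[C@@H]4CO[C@@](Cn5cncn5)(c5ccc(Cl)cc5Cl)O4)cc3)CC2)cc1` gives 5340 nM
compound 2 `O=C(CC1CCOCC1)Nc1ccc(N2CCN(c3ccc(OC[C@@H]4CO[C@@](Cn5cncn5)(c5ccc(Cl)cc5Cl)O4)cc3)CC2)cc1` gives 10000 nM
compound 3 `O=C(CCc1ccccc1)Nc1ccc(N2CCN(c3ccc(OC[C@@H]4CO[C@@](Cn5cncn5)(c5ccc(Cl)cc5Cl)O4)cc3)CC2)cc1` gives 2060 nM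

All three share one core and differ only in the group attached to the amide carbonyl. Compound 3 stands lowest of the three numbers: the steps of a 2.6-fold lower number from compound 1 to compound 3 (0.41 log units; beyond the scatter) and a 4.9-fold lower number from compound 2 to compound 3 (0.69 log units; beyond the scatter) both lie beyond the scatter, while the step of a 1.9-fold higher number from compound 1 to compound 2 (0.27 log units; within the scatter) lies within it. Compound 4 `O=C(Nc1ccc(N2CCN(c3ccc(OC[C@@H]4CO[C@@](Cn5cncn5)(c5ccc(Cl)cc5Cl)O4)cc3)CC2)cc1)c1cccc(F)c1` changes this same position again: 3-fluorophenyl in place of phenethyl on a carbonyl carbon. The two steps that bear on it, a 2.6-fold lower number from compound 1 to compound 3 (0.41 log units; beyond the scatter) and a 4.9-fold lower number from compound 2 to compound 3 (0.69 log units; beyond the scatter), each brought a modest lowering when an aromatic ring entered the chain. Going by the values given here, compound 4 keeps an aromatic ring but places it directly on the carbonyl carbon, a change no measured pair covers, so the expected step in this assay is small, most likely within the scatter, with a slight lean toward a lower number. Compound 4 is therefore estimated at 1800 nM, with a range of 600 nM to 5500 nM. The estimated step is a 1.1-fold lower number from compound 3 to compound 4 (0.06 log units; within the scatter).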

Compound 4, half-maximal inhibitory concentration: 6640 nM
For compound 4 the middle estimate is 3.7-fold (0.57 log units) below the measured one; the measured number lies above the stated range.
By their numbers in this assay, from the lowest: compound 3; then compounds 1, 4 and 2 (each within the scatter of the next).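

In this assay the lower number that came with phenethyl does not carry over to every aromatic group at this carbonyl carbon: a 3.2-fold higher number from compound 3 to compound 4 (0.51 log units; beyond the scatter) is a step beyond the scatter, so an aromatic ring in this group does not by itself give the lower number. Compound 4 instead falls in with the compounds that lack an aromatic ring here, with a 1.2-fold higher number from compound 1 to compound 4 (0.09 log units; within the scatter) and a 1.5-fold lower number from compound 2 to compound 4 (0.18 log units; within the scatter) both within the scatter, so butyl, (oxan-4-yl)methyl and 3-fluorophenyl cannot be told apart on these numbers. Nothing available explains why phenethyl stands apart from these groups.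

Compound 4 both loses the chain linking the ring to the carbonyl and gains a fluorine, and a plain phenyl or a 3-fluorophenethyl group would be needed to separate these two changes. Going by these compounds, how a longer chain ending in phenyl or an amine on the ring would read in this assay also stays open.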